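Trimming One Methyl from the Ester Chain

The source may hold more compounds than are shown below. What is called first, only, known or untested is meant among the compounds shown, and "the series" means these compounds.

Compound 1 `CC1=C(C(=O)OCc2ccccc2)C(c2ccoc2)NC(=O)N1` gives 41% in an assay on membranes from CHO cells for displacement of a labelled ligand from adenosine receptor A1 (Homo sapiens), read by scintillation counting, with a stated time of 60 min, tested at 1 uM; on this read-out lower numbers stand for less inhibition and higher numbers for more inhibition at the one concentration tested (going by the name of the read-out).
Compound 2 `CCCC(=O)C1=C(C)NC(=O)NC1c1ccoc1` gives 1%.
Compound 3 `CCC(CC)OC(=O)C1=C(C)NC(=O)NC1c1ccoc1` gives 17%.

Compound 3 stands second highest of these three numbers: a number 24 percentage points lower from compound 1 to compound 3 (beyond the scatter), while a number 16 percentage points higher from compound 2 to compound 3 (beyond the scatter). Compound 4 `CCC(C)OC(=O)C1=C(C)NC(=O)NC1c1ccoc1` differs from compound 3 by hydrogen in place of methyl on a saturated chain carbon, two bonds along the chain from an oxygen next to a carbonyl group. Neither measured step bears directly on this change: one exchanges pentan-3-yl for benzyl, the other exchanges (pentan-3-yl)oxy for propyl, and both replace the whole group rather than removing a single methyl from it. Both were modest in size. Going by the values given here, with no measured step of the same kind, no movement beyond the usual scatter is expected, and the estimated step is a number 2 percentage points lower from compound 3 to compound 4 (within the scatter). Compound 4 is therefore expected to give about 15%, with a range from 3% to 30%.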

Compound 4, a percentage reported as inhibition, at one concentration (the size of the read-out at that concentration, not a potency): 13%
For compound 4 the middle estimate is 2 percentage points above the measured one, and the stated range covers the measured number.
By their numbers in this assay, from the lowest: compound 2; then compounds 4 and 3 (each within the scatter of the next); then compound 1.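

Hydrogen in place of methyl on this saturated chain carbon gives a number 4 percentage points lower from compound 3 to compound 4 (within the scatter) in this assay, so this one methyl makes no difference that can be told from the scatter. The shorter sec-butoxy group still holds an advantage over propyl on the carbonyl carbon, with a number 12 percentage points higher from compound 2 to compound 4 (beyond the scatter). The sec-butyl group still falls short of benzyl, with a number 28 percentage points lower from compound 1 to compound 4 (beyond the scatter).

Open, from the compounds shown here alone, is how an isopropyl ester, or a benzyl ester carrying an amine on its ring, would read in this assay. Nothing measured here explains why these numbers differ.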